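The source may report more compounds than this note shows. Statements on the series, on what has been measured and on what is new or still open speak of the compounds shown alone.

Working notes on the quinoline-derived thiosemicarbazone series, read in a functional assay on HeLa cells (Homo sapiens) for antiproliferative activity, read by sulforhodamine B assay, with a stated time of 72 h; on this read-out lower numbers stand for stronger inhibition and higher numbers for weaker inhibition.

Of the compounds shown here, three have numbers so far. Compound 1 `S=C(N/N=C/c1ccc2ccccc2n1)Nc1cccc(Cl)c1` gives 52500 nM. Within the data shown here, compound 2 `N#Cc1ccc(NC(=S)N/N=C/c2ccc3ccccc3n2)cc1` gives 20000 nM, and the only single-point step among the measured compounds, a 2.6-fold lower number from compound 1 to compound 2 (0.42 log units; beyond the scatter), comes from 4-cyanophenyl in place of 3-chlorophenyl on the amide-type nitrogen. Compound 3 `FC(F)(F)c1ccccc1NC(=S)N/N=C/c1ccc2ccccc2n1` gives 18800 nM; this is the lowest of the three numbers, though its gap to compound 2 lies within the scatter, so the two cannot be ordered, while its gap to compound 1 lies beyond the scatter.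

Compound 4 `S=C(N/N=C/c1ccc2ccccc2n1)Nc1ccccc1Br` is not yet measured. It differs from compound 3 by bromo in place of trifluoromethyl on an aromatic carbon. Among the measured compounds shown here, no measured step touches this position of the aryl ring, and the one measured step changes a different substituent at a different place, so it bears only loosely on the question. The aryl substituent variations seen so far, from compound 1 to compound 2 and on to compound 3, span a modest range, and a change at the site ortho to the large group is expected to stay within that range. The expected step is a 1.3-fold higher number from compound 3 to compound 4 (0.12 log units; within the scatter), which is within the scatter, in neither direction.

Compound 4 is therefore estimated at 25000 nM in this assay, with a range from 9000 nM to 70000 nM.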

Compound 4, half-maximal inhibitory concentration: > 100000 nM
Compound 4 ended at the assay's limit; the forecaster's own chance of this, stated with the estimate: 10%; middle value at least 4.0-fold (0.60 log units) away from the limit.
By their numbers in this assay, from the lowest: compounds 3 and 2 (each within the scatter of the next); then compound 1. At a limit, above all of these: compound 4.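

Compound 4 stands at a limit of this assay, not at a number: the limit of > 100000 nM in this assay, at which 1 of the 4 values shown sits. Bromo in place of trifluoromethyl on an aromatic carbon, ortho to a large group, gives an at least 5.3-fold higher number from compound 3 to compound 4 (0.72 log units; beyond the scatter), an at least modest step, so the number in this assay changes with the group at this place on the aryl ring, which no earlier step showed. 2-Bromophenyl in place of 4-cyanophenyl on the amide-type nitrogen gives an at least 5.0-fold higher number from compound 2 to compound 4 (0.69 log units; beyond the scatter), while 2-bromophenyl in place of 3-chlorophenyl on the amide-type nitrogen gives an at least 1.9-fold higher number from compound 1 to compound 4 (0.27 log units; that floor lies within the scatter), a step that cannot be read.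

As far as these compounds go, the true size of these steps stays open, as each rests on a limit. Also open, from the compounds shown here alone, is whether a different group at this place, such as an amine or a carboxylic acid, would stay near compound 3 or go the way of compound 4.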